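The compounds below may be only part of what the source reports. "The series", "measured", "known", "first", "only" and "open" are said of these compounds alone.

In a functional assay on A-375 cells (Homo sapiens) for activation, with a stated time of 3 days (a higher number here means that more compound is needed for the effect, a lower number that less compound is needed), compound 1 `O=C(Nc1ccc(-c2cscn2)cc1)[C@@H]1CCCN(Cc2ccc(F)c(F)c2)C1` gives 4000 nM, while compound 2 `O=C(Nc1ccc(-c2cscn2)cc1)[C@H]1CCCN(Cc2ccc(F)c(F)c2)C1` gives 270 nM, the lower of the two numbers. Among the measured compounds shown here, the only measured step, a 15-fold lower number from compound 1 to compound 2 (1.17 log units; beyond the scatter), is large, and it stems from the fact that compounds 1 and 2 differ only in the configuration as drawn. Compound 3 `O=C(Nc1ccc(-c2ccc[nH]2)cc1)[C@H]1CCCN(Cc2ccc(F)c(F)c2)C1` keeps the configuration of compound 2 and carries a single change: 1H-pyrrol-2-yl in place of 1,3-thiazol-4-yl on an aromatic carbon, para to a large group. The measured step concerns configuration alone and gives no direct guide to this exchange of rings, so its size cannot be carried over. No shift beyond the scatter in this assay is therefore expected in either direction, though the uncertainty is wide. The expected change is a 1.1-fold higher number from compound 2 to compound 3 (0.05 log units; within the scatter). For compound 3 the estimate is 300 nM, with an expected range from 80 nM to 1200 nM.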

Compound 3, half-maximal effective concentration: 140 nM
The estimate for compound 3 lay 2.1-fold (0.33 log units) above the measured number; low and high end bracket the measured number.
By their numbers in this assay, from the lowest: compounds 3 and 2 (each within the scatter of the next); then compound 1.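

In this assay the exchange of 1,3-thiazol-4-yl for 1H-pyrrol-2-yl, on an aromatic carbon para to a large group, gives a 1.9-fold lower number from compound 2 to compound 3 (0.29 log units; within the scatter) and so shows that this position takes a second five-membered aromatic ring with no shift beyond the scatter. The earlier compounds shown here spoke only to configuration, whereas this pair varies the ring itself: sulfur and the hydrogen-bond acceptors of 1,3-thiazol-4-yl leave, the hydrogen-bond donor of 1H-pyrrol-2-yl enters, and the number stays within the scatter. Nothing known here bears on why these two rings stand so close.

The compounds shown leave open how this position responds to a group of another kind, such as a carboxylic acid or an amine. Going by these compounds, whether the large step in configuration seen with 1,3-thiazol-4-yl also holds with 1H-pyrrol-2-yl stays open as well.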